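This account rests on a few compounds, and the source may have more. Where it says the series, first, only, none or still open, it means among the compounds named here.

Measured in a functional assay on L6 cells (Rattus norvegicus) for cytotoxicity; on this read-out lower numbers stand for stronger inhibition and higher numbers for weaker inhibition:
- compound 1 `CONC(=N)c1ccc(-c2ccc(-c3ccc(C(=N)NOC)cc3)c(F)c2)cc1`: 8500 nM
- compound 2 `CONC(=N)c1ccc(-c2ccc(-c3ccc(C(=N)NOC)cc3)c(C(F)(F)F)c2)cc1`: 42200 nM

Compound 2 holds the higher of the two numbers, at 42200 nM. Compound 3 `CONC(=N)c1ccc(-c2ccc(-c3ccc(C(=N)NOC)cc3)cc2)cc1` has not yet been measured. It differs from compound 2 by hydrogen in place of trifluoromethyl on an aromatic carbon, ortho to a large group and meta to a large group. For the measured compounds named here, one measured step bears on this change: a 5.0-fold higher number from compound 1 to compound 2 (0.70 log units; beyond the scatter), modest but beyond the scatter, for trifluoromethyl in place of fluoro at the same place. Going by the values given here, no measured compound other than compound 3's neighbours varies this place, and the effect of hydrogen there is untested. Removing trifluoromethyl is therefore expected to give a step of similar size toward a lower number. The expected change is a 4.2-fold lower number from compound 2 to compound 3 (0.63 log units; beyond the scatter) in this assay. For compound 3 the estimated value is 10000 nM, with an expected range of 3500 nM to 30000 nM.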

Compound 3, half-maximal inhibitory concentration: 118000 nM
The estimate for compound 3 lay 12-fold (1.07 log units) below the measured number; measured number outside the range, above it.
By their numbers in this assay, from the lowest: compound 1; then compound 2; then compound 3.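

In this assay, removing the substituent does not reverse the earlier trifluoromethyl step: hydrogen in place of trifluoromethyl moves the number further up (a 2.8-fold higher number from compound 2 to compound 3 (0.45 log units; beyond the scatter)), not down. Hydrogen in place of fluoro gives the largest step in the set (a 14-fold higher number from compound 1 to compound 3 (1.14 log units; beyond the scatter)), so among these three compounds hydrogen carries the highest number and fluoro the lowest, with trifluoromethyl in between rather than at the far end. Nothing available accounts for this order.

Going by these compounds, whether other groups at this place, such as chloro, methoxy or an amine, would also give lower numbers than hydrogen, or would fall below fluoro, remains open. On these data alone, the order is also known only from this assay, and whether it holds for the same three compounds on other cells remains open.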